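The compounds below may be only part of what the source reports. "The series", "measured", "known", "first", "only" and "open" are said of these compounds alone.

In a physicochemical assay for lipophilicity, at pH 7.4 (on this read-out higher numbers stand for higher lipophilicity and lower numbers for lower lipophilicity), compound 3 `COC(=O)c1cc(N)c(Nc2ccc(C#N)cc2)cc1Oc1c(C)cc(/C=C/C#N)cc1C` gives 4.15. Compound 2 `COC(=O)c1cc(N)c(Nc2ccc(C#N)cc2)cc1Oc1c(C)cc(CCC#N)cc1C` gives 4.15, level with compound 3 at the digits shown, while compound 1 `CNC(=O)c1cc(N)c(Nc2ccc(C#N)cc2)cc1Oc1c(C)cc(CCC#N)cc1C` gives 2.65. Compound 4 `CNC(=O)c1cc(N)c(Nc2ccc(C#N)cc2)cc1Oc1c(C)cc(/C=C/C#N)cc1C` has not yet been measured. It differs from compound 3 in one place: methylamino in place of methoxy on a carbonyl carbon, with methylamino in place of methoxy on a carbonyl carbon.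

Among the compounds with values here, two measured steps bear on this change. The same two groups, exchanged in the opposite direction, gave a large step: a number 1.50 log units higher from compound 1 to compound 2 (beyond the scatter). Within the data shown here, replacing 2-cyanoethyl with 2-cyanoethenyl on an aromatic carbon gave no change at the digits printed from compound 2 to compound 3 (within the scatter), so the two side chains differ by nothing beyond the scatter in the one pair measured. Among the measured compounds shown here, the exchange at the carbonyl carbon therefore is expected to carry over with about the same size, reversed in sign, although only a single pair supports it. The expected change in this assay is a number 1.50 log units lower from compound 3 to compound 4 (beyond the scatter). Compound 4 is estimated at 2.65, with an expected range from 2.25 to 3.05.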

Compound 4, partition coefficient: 4.12
The estimate for compound 4 lay 1.47 log units below the measured number; measured number above the stated range.
By their numbers in this assay, from the lowest: compound 1; then compounds 4, 2 and 3 (each within the scatter of the next).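

In this assay the exchange of methoxy for methylamino on a carbonyl carbon proves to depend on the side chain: with 2-cyanoethyl present the exchange read in reverse gives a number 1.50 log units higher from compound 1 to compound 2 (beyond the scatter) while with 2-cyanoethenyl present it gives a number 0.03 log units lower from compound 3 to compound 4 (within the scatter) and not a step of that size. The side-chain exchange, which showed nothing with methoxy, likewise gives a number 1.47 log units higher from compound 1 to compound 4 (beyond the scatter) when methylamino is present, so the two exchanges do not add and compound 1 alone stands apart among the four. Nothing available accounts for this interplay.

Within the data shown here, each exchange rests on only two pairs, so it remains open whether the low number is confined to the pairing of methylamino with 2-cyanoethyl. As far as these compounds go, how ethylamino on the carbonyl carbon would read with each of the two side chains, or how methylamino would read with a 3-cyanopropyl chain, also remains open.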